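Positional methyl shift on the amine nitrogen, anti-inflammatory series

The source may report more compounds than this note shows. Statements on the series, on what has been measured and on what is new or still open speak of the compounds shown alone.

Measured so far:
compound 1 `Cc1ccc(N(C)CC2CCC/C(=C\c3ccccc3)C2=O)cc1` — 25.5%
compound 2 `Cc1cccc(N(C)CC2CCC/C(=C\c3ccccc3)C2=O)c1` — 46.8%
compound 3 `Cc1ccc(N(C)CC2CCC/C(=C\c3ccccc3)C2(O)c2ccccc2)cc1` — 59.6%

In a functional assay on the whole organism (strain Wistar) for inhibition, with Rattus norvegicus as the target, read by paw edema, with stated times of 1 h and 3 h, at a dose of 200 mg/kg by the oral route (on this read-out higher numbers stand for more inhibition at the one dose given (going by the name of the read-out) and lower numbers for less inhibition), compound 1 gives 25.5% and compound 2 gives 46.8%. The change between them, (3-methylphenyl in place of 4-methylphenyl on an amine nitrogen), made a step of a number 21.3 percentage points higher from compound 1 to compound 2 (beyond the scatter). Compound 3, on a different core, gives 59.6% in this assay, the highest of the three; the difference between its core and that of compound 1 is not broken down here.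

Compound 4 `Cc1cccc(N(C)CC2CCC/C(=C\c3ccccc3)C2(O)c2ccccc2)c1` is not yet measured. It differs from compound 3 by 3-methylphenyl in place of 4-methylphenyl on an amine nitrogen, the same change as from compound 1 to compound 2, at the same place. Resting on the step of a number 21.3 percentage points higher from compound 1 to compound 2 (beyond the scatter), a positive step is expected for compound 4, estimated at a number 14.4 percentage points higher from compound 3 to compound 4 (beyond the scatter), somewhat smaller since compound 3 already stands high. Compound 4 is estimated at 74%, expected between 58% and 88%.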

Compound 4, a percentage reported as inhibition, in the whole organism at one dose (the size of the read-out at that dose, not a potency): 36.2%
Compound 4: middle estimate off by 37.8 percentage points, on the high side; measured number below the stated range.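

In this assay, 3-methylphenyl in place of 4-methylphenyl on the amine nitrogen gives a number 23.4 percentage points lower from compound 3 to compound 4 (beyond the scatter), so the step does not carry from the core of compound 1 to the core of compound 3, even in sign: the same change on two cores in this assay, a number 21.3 percentage points higher (beyond the scatter) from compound 1 to compound 2 and a number 23.4 percentage points lower (beyond the scatter) from compound 3 to compound 4, 44.7 percentage points apart, beyond the scatter of two such steps

In these two pairs, the outcome of this change depends on the core it sits on. Two pairs at a single dose do not show what in the core reverses the step, nor whether the reversal extends beyond these compounds.

Open, going by these compounds, is how both cores respond to an unsubstituted phenyl on the amine nitrogen. Also open, on these data alone, is whether a chloro or methoxy group in place of the ring methyl shows the same reversal.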